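Amide-to-urea step with a dichlorophenyl end on compound 4

A few compounds are considered here, and "the series" means these few. Any claim that something is new, unique, unknown or untested is made for them only; others in the source may bear on it.

Compound 1 `COc1cc(-c2nn(-c3cccc(NC(=O)c4cccc(C(F)(F)F)c4)c3)cc2-c2ccncc2)ccc1Cl` gives 1940 nM in a functional assay on UACC-62 cells (Homo sapiens) for inhibition, read by sulforhodamine B assay, with a stated time of 48 h (on this read-out lower numbers stand for stronger inhibition of growth and higher numbers for weaker inhibition of growth), the highest of the three numbers; its nearest neighbour is compound 2 `COc1cc(-c2nn(-c3cccc(NC(=O)Nc4cccc(C(F)(F)F)c4)c3)cc2-c2ccncc2)ccc1Cl` at 725 nM, and compound 3 `O=C(Nc1cccc(-n2cc(-c3ccncc3)c(-c3ccc(Cl)c(O)c3)n2)c1)Nc1ccc(Cl)c(C(F)(F)F)c1` gives 627 nM. Compound 4 `COc1cc(-c2nn(-c3cccc(NC(=O)Nc4ccc(Cl)c(Cl)c4)c3)cc2-c2ccncc2)ccc1Cl` is not yet measured. Its change from compound 1 is (3,4-dichlorophenyl)amino in place of 3-(trifluoromethyl)phenyl on a carbonyl carbon. For the measured compounds named here, the one directly comparable step is a 2.7-fold lower number from compound 1 to compound 2 (0.43 log units; beyond the scatter), where (3-(trifluoromethyl)phenyl)amino replaced 3-(trifluoromethyl)phenyl on the same carbonyl carbon. Compound 4 shares that change in kind and only alters the aryl end to 3,4-dichlorophenyl; compound 3 shows a value close to compound 2 with a different aryl end, though on a different core. Compound 4 is therefore expected to step a 2.8-fold lower number from compound 1 to compound 4 (0.44 log units; beyond the scatter), landing near compound 2. The estimate for compound 4 is 700 nM, within 250 nM to 2000 nM.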

Compound 4, concentration for 50% growth inhibition: 773 nM
Compound 4: middle estimate off by 1.1-fold (0.04 log units), on the low side; the measured number falls inside the stated range.
By their numbers in this assay, from the lowest: compounds 3, 2 and 4 (each within the scatter of the next); then compound 1.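

In this assay, the urea keeps its advantage over the amide of compound 1 when the aryl end is 3,4-dichlorophenyl, with a 2.5-fold lower number from compound 1 to compound 4 (0.40 log units; beyond the scatter). On the amide-type nitrogen, 3,4-dichlorophenyl and 3-(trifluoromethyl)phenyl are not told apart, with a 1.1-fold higher number from compound 2 to compound 4 (0.03 log units; within the scatter). No measurement available here explains either step.

Open, on these data alone, is how the amide would read with a 3,4-dichlorophenyl end, which would separate the contribution of the aryl end from that of the added amino nitrogen. Also open, as far as these compounds go, is whether a cyclohexyl end, or an aryl end carrying a carboxylic acid, would hold this level.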